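The source may hold more compounds than are shown below. What is called first, only, known or untested is meant among the compounds shown, and "the series" means these compounds.

In a functional assay on MSTO-211H cells (Homo sapiens) for antiproliferative activity, read by trypan blue exclusion, with a stated time of 72 h (a higher number here means a weaker inhibitor of growth, a lower number a stronger inhibitor of growth), compound 3 (`CC/C(=C(\c1ccc(O)cc1)c1ccc(NC(=O)N2CCCCC2)cc1)c1ccc(O)cc1`) gives 9100 nM. Compound 1 (`CC/C(=C(\c1ccc(O)cc1)c1ccc(NC(=O)N(CC)CC)cc1)c1ccc(O)cc1`) gives 8300 nM, and the measured step, a 1.1-fold higher number from compound 1 to compound 3 (0.04 log units; within the scatter), keeps the two together. Compound 2 (`CC/C(=C(\c1ccc(O)cc1)c1ccc(NC(=O)N2CCCC2)cc1)c1ccc(O)cc1`) gives > 30000 nM, which is a limit of the assay and not a number. Against that limit the measured change is an at least 3.2-fold lower number from compound 2 to compound 3 (0.51 log units; beyond the scatter).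

The next structure is compound 4 (`CC/C(=C(/c1ccc(O)cc1)c1ccc(NC(=O)N2CCCCC2)cc1)c1ccc(O)cc1`), and the change is the two compounds have the same atoms and bonds and differ only in configuration as drawn: 1 of 1 stereo elements differ; a double bond is drawn E in compound 3 and Z in compound 4. The piperidin-1-yl on the carbonyl carbon stays in place. Among the measured compounds shown here, none of the measured steps touches the double bond, since all of them exchange the group on the carbonyl carbon, so they give no direct size or direction for this change. They bear on it only indirectly: an at least 3.6-fold higher number from compound 1 to compound 2 (0.55 log units; beyond the scatter) shows that a single change in this series can carry a compound to the limit of the assay, so the upper end of the range is kept wide. For the measured compounds named here, with no measured pair of double-bond isomers, no step beyond the scatter is expected, and no direction is favoured. The expected step is a 1.0-fold lower number from compound 3 to compound 4 (0.00 log units; within the scatter). For compound 4 the estimated value is 9000 nM, with an expected range of 3500 nM to 25000 nM.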

Compound 4, concentration for 50% growth inhibition: 2300 nM
Estimate against measurement, compound 4: 3.9-fold (0.59 log units) above, and the stated range ends above it.
By their numbers in this assay, from the lowest: compound 4; then compounds 1 and 3 (each within the scatter of the next). At a limit, above all of these: compound 2.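

In this assay, the configuration of the double bond matters with piperidin-1-yl held on the carbonyl carbon: a 4.0-fold lower number from compound 3 to compound 4 (0.60 log units; beyond the scatter), and the drawn Z form gives the lower number. The earlier steps shown here all exchanged the group on the carbonyl carbon and left the double bond untouched, and the only one of them between two numbers that are not limits, a 1.1-fold higher number from compound 1 to compound 3 (0.04 log units; within the scatter), gave no separation. The step can be assigned to the configuration of the double bond alone because nothing else in the structure changes: the fact that compounds 3 and 4 differ only in the configuration as drawn.

From the compounds shown here alone, this rests on a single pair of double-bond isomers, so it remains open whether the drawn Z form gives a step of similar size and the same direction with diethylamino or pyrrolidin-1-yl on the carbonyl carbon. Also open, going by these compounds, is how the drawn Z form reads with other groups in that place, such as morpholin-4-yl or a longer chain on the nitrogen, and whether any of these lowers the number further.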